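The compounds below may be only part of what the source reports. "The series", "measured", "known", "first", "only" and "open" are said of these compounds alone.

Compound 1 `C/C=C/C(=O)N(Cc1ccc(OC)c([N+](=O)[O-])c1)c1cc(OC)c(OC)c(OC)c1`: 670 nM
Compound 2 `COc1ccc(CN(C(=O)C(C)Br)c2cc(OC)c(OC)c(OC)c2)cc1O`: 140 nM
Compound 3 `COc1cc(NCc2ccc(Cl)cc2)cc(OC)c1OC`: > 80000 nM
Compound 4 `COc1ccc(CN(C(=O)CN=[N+]=[N-])c2cc(OC)c(OC)c(OC)c2)cc1O`: not yet measured

All of these values come from a functional assay on HCT-116 cells (Homo sapiens) for inhibition, read by MTT assay, with a stated time of 48 h; on this read-out higher numbers stand for weaker inhibition and lower numbers for stronger inhibition. Compound 2 gives 140 nM, the lower of the two true numbers. Its nearest neighbour, compound 1, gives 670 nM, a gap beyond the usual scatter. Compound 3 reads > 80000 nM, which is a limit of the assay and not a number.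

Compound 4 keeps the rest of compound 2 but carries azidomethyl in place of 1-bromoethyl on a carbonyl carbon. Going by the values given here, no measured pair of compounds shows a change of this kind, so any forecast is uncertain. Starting from compound 2 at 140 nM, the lowest number so far, a moderate move towards a higher number and weaker inhibition in this assay is expected, probably beyond the scatter. The expected change is a 4.3-fold higher number from compound 2 to compound 4 (0.63 log units; beyond the scatter). For compound 4, the estimated value is 600 nM, with an expected range from 100 nM to 5000 nM.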

Compound 4, half-maximal inhibitory concentration: 410 nM
Compound 4: the middle estimate sits 1.5-fold (0.17 log units) above what was measured, within the range that was stated.
By their numbers in this assay, from the lowest: compound 2; then compounds 4 and 1 (each within the scatter of the next). At a limit, above all of these: compound 3.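

Swapping 1-bromoethyl for azidomethyl on a carbonyl carbon in this assay gives a 2.9-fold higher number from compound 2 to compound 4 (0.47 log units; beyond the scatter) and is the first change in this set made at a single place. It therefore gives the first direct sign that the group on this carbonyl carbon affects the read-out, although the step is modest. Bromine is also not essential for activity at this level, as compound 4 still reads 410 nM without any bromine, and nothing shown here accounts for the size of the step.

The change alters both the bromine-versus-azide identity and the carbon count of the group, so the step cannot separate these two differences. Bromomethyl and 1-azidoethyl would pull them apart, while a plain methyl or an aminomethyl group would show how much this position tolerates.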